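The source may report more compounds than this note shows. Statements on the series, on what has been measured and on what is new or still open speak of the compounds shown alone.

Measured so far in a functional assay on the whole organism for inhibition of sodium-dependent dopamine transporter (Mus musculus); a lower number here means that less compound is needed, a higher number that more compound is needed for the effect:
- Compound 1, `CCNC(=O)Nc1cccc2c1CN(C)CC2c1ccccc1`: compound 1 gives only a limit, > 80 mg/kg.
- Compound 2, `CN1Cc2c(NC(=O)OCc3ccccc3)cccc2C(c2ccccc2)C1`: compound 2 gives 25 mg/kg.
- Compound 3, `CCNCC(=O)Nc1cccc2c1CN(C)CC2c1ccccc1`: compound 3 gives about 60 mg/kg.

Compound 3 stands highest of the two numbers; the gap to the nearest is a 2.4-fold higher number from compound 2 to compound 3 (0.38 log units; beyond the scatter). Compound 4, `CC(C)NCCC(=O)Nc1cccc2c1CN(C)CC2c1ccccc1`, differs from compound 3 in one place: (isopropylamino)methyl in place of ethylamino on a saturated chain carbon bound to a carbonyl carbon. Within the data shown here, the one measured step of a similar kind, a lengthening of the chain on the carbonyl carbon, is an at least 1.3-fold lower number from compound 1 to compound 3 (0.12 log units; that floor lies within the scatter), and its floor lies within the scatter, so it gives no clear direction. Among the measured compounds shown here, no measured step covers the isopropyl group. Compound 4 is therefore expected to move only a 1.2-fold lower number from compound 3 to compound 4 (0.08 log units; within the scatter), a shift within the scatter. Compound 4 is estimated at 50 mg/kg, with a range from 20 mg/kg to 150 mg/kg.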

Compound 4, dose for half-maximal effect: about 200 mg/kg
Estimate against measurement, compound 4: 4.0-fold (0.60 log units) below; measured number outside the range, above it.
By their numbers in this assay, from the lowest: compound 2; then compound 3; then compound 4.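

In this assay, the earlier lengthening of the chain on the carbonyl carbon gave no clear direction, but this change does: (isopropylamino)methyl in place of ethylamino gives a 3.3-fold higher number from compound 3 to compound 4 (0.52 log units; beyond the scatter). With benzyloxy replaced by 2-(isopropylamino)ethyl on the carbonyl carbon, the step is an 8.0-fold higher number from compound 2 to compound 4 (0.90 log units; beyond the scatter). The step from compound 1 cannot be read, since compound 1 gives only a limit: the limit of > 80 mg/kg in this assay, at which 1 of the 4 values shown sits.

This single change adds chain length and swaps ethyl for isopropyl, so the two remain unseparated. A 2-(ethylamino)ethyl chain would change the length alone, and an isopropylaminomethyl chain the end group alone.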